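The source may report more compounds than this note shows. Statements on the series, on what has been measured and on what is new or still open speak of the compounds shown alone.

Compound 1, with the structure `O=C(OCc1cc(C(F)(F)F)cc(C(F)(F)F)c1)[C@]1(c2ccccc2)CC[C@@H](N2CCC(c3ccc(F)cc3)CC2)CC1`, carries an ester linkage to the bis(trifluoromethyl)benzyl group, and in an assay on isolated protein for displacement of a labelled ligand from Substance-P receptor (Homo sapiens) (a lower number here means a stronger inhibitor, a higher number a weaker inhibitor), compound 1 gives 140 nM. Compound 2, with the structure `O=C(NCc1cc(C(F)(F)F)cc(C(F)(F)F)c1)[C@]1(c2ccccc2)CC[C@@H](N2CCC(c3ccc(F)cc3)CC2)CC1`, replaces that ester by an amide, and in this assay compound 2 gives 150 nM. Of the two numbers recorded, compound 2 has the higher one, but its distance to compound 1 is well within the scatter, so the two compounds are best read as equivalent in this assay.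

Compound 3, with the structure `O=C(NCc1cc(C(F)(F)F)cc(C(F)(F)F)c1)[C@]1(c2ccccc2)CC[C@H](N2CCC(c3ccc(F)cc3)CC2)CC1`, is the next compound to be measured. Relative to compound 2 it changes as follows: the two compounds have the same atoms and bonds and differ only in configuration as drawn: 2 of 2 stereo elements differ (all stereocentres are inverted: mirror images); a stereocentre at a saturated ring carbon is drawn r in compound 2 and s in compound 3; a stereocentre at a saturated ring carbon is drawn r in compound 2 and s in compound 3. Among the measured compounds shown here, no step between measured compounds of this kind is available, so there is no measured precedent for what the inverted configuration does here. A change of configuration at both saturated ring carbons can reshape the whole molecule, and a loss of affinity beyond the scatter is expected for compound 3, though with considerable uncertainty in size. The step from compound 2 to compound 3 is estimated at a 4.7-fold higher number from compound 2 to compound 3 (0.67 log units; beyond the scatter). For compound 3 in this assay the estimated value is 700 nM, with a plausible range from 120 nM to 4000 nM.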

Compound 3, half-maximal inhibitory concentration: 0.34 nM
The estimate for compound 3 lay 2100-fold (3.31 log units) above the measured number; measured number below the stated range.
By their numbers in this assay, from the lowest: compound 3; then compounds 1 and 2 (each within the scatter of the next).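

Inverting both stereocentres at the saturated ring carbons gives a 440-fold lower number from compound 2 to compound 3 (2.64 log units; beyond the scatter) in this assay, which shows that the configuration at these two positions has a very large bearing on the value in this series. The earlier pair could not show this: compound 1 and compound 2 share one configuration as drawn, and their exchange of ester for amide left the two values within the scatter of each other, whereas the present change reaches compound 3 at 0.34 nM. The step can be tied to configuration alone, because nothing else separates the two structures: the fact that compounds 2 and 3 differ only in the configuration as drawn

The two stereocentres change together here, so the compounds shown do not tell how much of the step belongs to either ring carbon, nor whether the ester linkage of compound 1 would follow the amide when drawn in the configuration of compound 3. They also leave open whether a sulfonamide in place of the amide, or a methyl group on the amide nitrogen, would keep the value of compound 3 in this assay.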